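This account rests on a few compounds, and the source may have more. Where it says the series, first, only, none or still open, it means among the compounds named here.

Compound 1, `COc1ccc(-c2cnc(NC(=O)c3ccc(O)cc3)n2C)cc1`, is examined in a toxicity assay on THP-1 cells (Homo sapiens) for inhibition (on this read-out lower numbers stand for higher toxicity in this test and higher numbers for lower toxicity in this test), where compound 1 gives > 100000 nM; this is a limit of the assay and not a measured number. Compound 2, `COc1ccc(-c2ccc(NC(=O)c3ccc(F)cc3)nc2)cc1`, gives > 100000 nM in this assay, again a limit rather than a number. For the measured compounds named here, compound 3, `Cc1ccc(C(=O)Nc2ncc(-c3ccccc3)o2)cc1`, gives 26000 nM in this assay, the only number among the three values. Going by the values given here, no pair of measured compounds differs in just one place, so no step between them can be counted, and the three values stand side by side without a measured link. Where compound 1 stands is told by the limit of > 100000 nM in this assay, at which 2 of the 3 values shown sit.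

Compound 4, `COc1ccc(-c2cnc(NC(=O)c3ccc(F)cc3)n2C)cc1`, differs from compound 1 by fluoro in place of hydroxy on an aromatic carbon. Compound 2 also carries a 4-fluorophenyl amide, on a different core, and its value is a limit. With both compound 1 and compound 2 at the limit, the step is expected to be a step that the limit leaves unreadable from compound 1 to compound 4, no shift beyond the usual scatter in this assay. Compound 4 is therefore estimated to give 150000 nM in this assay, within a range from 60000 nM to 400000 nM, most probably reported once more as a limit rather than as a number.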

Compound 4, half-maximal cytotoxic concentration: >= 50000 nM
Compound 4 ended at the assay's limit (the forecaster's own chance of this, stated with the estimate: 75%); the middle value lies beyond the limit too.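

Compound 1 and compound 4 each give only a limit in this assay, not a number, and the step between them, fluoro in place of hydroxy on an aromatic carbon, cannot be read. The compounds shown leave open whether going from 4-hydroxyphenyl to 4-fluorophenyl changes this read-out at all, and by how much.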